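The source may report more compounds than this note shows. Statements on the series, on what has been measured and on what is new or still open speak of the compounds shown alone.

Working notes on the series. For the measured compounds named here, compound 2 `COc1ccc(/C=C2\Cc3c(cc(OC)c(OC)c3OC)C2=O)cc1OC` is the second of two compounds so far, and in a functional assay on PC-3 cells (Homo sapiens) for antiproliferative activity, read by MTT assay, with a stated time of 48 h (a lower number here means a stronger inhibitor of growth, a higher number a weaker inhibitor of growth), compound 2 gives 7470 nM, the highest of the two numbers. The nearest is compound 1 `COc1ccc(/C=C2\Cc3c(cc(OC)c(OC)c3OC)C2=O)cc1`, which in this assay gives 750 nM. Going by the values given here, the one step between them, a 10-fold higher number from compound 1 to compound 2 (1.00 log units; beyond the scatter), is the only measured step that touches the position now changed. Compound 3 `COc1ccc(/C=C2\Cc3c(cc(OC)c(OC)c3OC)C2=O)cc1F` differs from compound 2 by fluoro in place of methoxy on an aromatic carbon. Among the compounds with values here, no measured pair shows fluoro against methoxy, so the expectation rests on the single step, which puts methoxy at this carbon and raised the number beyond the scatter; fluoro is a smaller group at the same place, so part of that rise is expected to be undone, and the step of a 3.4-fold lower number from compound 2 to compound 3 (0.53 log units; beyond the scatter) is expected in this assay. Compound 3 is estimated at 2200 nM, within 700 nM to 7000 nM.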

Compound 3, concentration for 50% growth inhibition: 277 nM
Estimate against measurement, compound 3: 7.9-fold (0.90 log units) above, and the stated range ends above it.
By their numbers in this assay, from the lowest: compound 3; then compound 1; then compound 2.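

In this assay this aromatic carbon is not a place where any added group raises the number: a 2.7-fold lower number from compound 1 to compound 3 (0.43 log units; beyond the scatter), so fluoro moves the number the opposite way from methoxy at the same carbon. The exchange of the two groups, a 27-fold lower number from compound 2 to compound 3 (1.43 log units; beyond the scatter), is the largest step seen in the series, and hydrogen falls between fluoro and methoxy in the order of the numbers, so the group at this carbon can move the number in either direction. No measurement on these compounds accounts for this reversal.

Going by these compounds, whether the lowering is particular to fluoro, or also appears with chloro, a nitrile or a hydroxyl at this carbon, remains open. Also open, on these data alone, is whether an amine or a longer chain such as ethoxy would follow methoxy here.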